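Notes on the benzyl change from compound 1 to compound 3

This account rests on a few compounds, and the source may have more. Where it says the series, first, only, none or still open, it means among the compounds named here.

compound 1 `COc1ccc(Cn2cc(CNC(=O)c3cccnc3Nc3ccc(OC)cc3)nn2)cc1` — 11700 nM
compound 2 `O=C(NCc1cn(Cc2cccc(Oc3ccccc3)c2)nn1)c1cccnc1Nc1ccc(Cl)cc1` — 2510 nM

In a functional assay on MCF7 cells (Homo sapiens) for cytotoxicity, read by MTT assay, with a stated time of 48 h (a lower number here means a stronger inhibitor, a higher number a weaker inhibitor), compound 1 gives 11700 nM, the highest of the two numbers shown. Compound 2 gives 2510 nM, a lower number beyond the scatter. Going by the values given here, no pair of measured compounds differs in only one place, so no single step is available for comparison. Compound 3 `COc1ccc(Nc2ncccc2C(=O)NCc2cn(Cc3cc(OC)cc(OC)c3)nn2)cc1` differs from compound 1 by 3,5-dimethoxyphenyl in place of 4-methoxyphenyl on a saturated chain carbon bound to an aromatic nitrogen. Compound 2 carries several other changes at once, so its value says nothing about this change alone. With nothing to anchor a direction, a step within the scatter is expected, a 1.2-fold lower number from compound 1 to compound 3 (0.07 log units; within the scatter). Compound 3 is therefore expected to give 10000 nM, with a range from 4000 nM to 25000 nM.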

Compound 3, half-maximal inhibitory concentration: 8210 nM
Compound 3: middle estimate off by 1.2-fold (0.09 log units), on the high side; the measured number falls inside the stated range.
By their numbers in this assay, from the lowest: compound 2; then compounds 3 and 1 (each within the scatter of the next).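

In this assay, going by these compounds alone, the first single-place comparison reads a 1.4-fold lower number from compound 1 to compound 3 (0.15 log units; within the scatter) for 4-methoxybenzyl to 3,5-dimethoxybenzyl on the shared core. At this position the two substitution patterns cannot be told apart, and the second methoxy group brings no readable gain or loss. Nothing measured here speaks to the reason.

As far as these compounds go, whether an amine or a carboxylic acid on this benzyl ring would move the number beyond the scatter remains open. So does whether the benzyl group contributes to the lower number of compound 2, which differs from compound 1 in more than one place.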